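Methylamino for methyl on the carbonyl of compound 2

The compounds below may be only part of what the source reports. "The series", "measured", "known", "first", "only" and "open" are said of these compounds alone.

Measured so far:
compound 1, `CCCCCCCN1C(=O)[C@H](Cc2ccc(-c3cc(OC)c(OC)c(OC)c3)cc2)N(C)C(=O)[C@@H]1C`, gives 54%
compound 2, `CCCCCCCCN1C(=O)[C@H](Cc2ccc(-c3cccc(CN(CCCC)C(C)=O)c3)cc2)N(C)C(=O)[C@@H]1C`, gives 57%

Both numbers come from a functional assay on cells for agonist activity at follicle-stimulating hormone receptor (Homo sapiens), read by cAMP accumulation; a lower number here means a smaller maximal response, a higher number a larger maximal response. Compound 2 shows the higher of the two values, but compound 1 sits within the usual scatter of it, so the two are taken as equivalent on this read-out. For the measured compounds named here, no pair differs in only one place, so no single-point step is available to size a change of this kind.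

Compound 3, `CCCCCCCCN1C(=O)[C@H](Cc2ccc(-c3cccc(CN(CCCC)C(=O)NC)c3)cc2)N(C)C(=O)[C@@H]1C`, is not yet measured. Its difference from compound 2 is methylamino in place of methyl on a carbonyl carbon. The change sits on the carbonyl carbon whose other neighbour is the amide-type nitrogen, with the rest of the molecule, including the octyl chain and the core, unchanged.

Going by the values given here, with only two measured compounds and both within scatter of each other, the expected step from compound 2 to compound 3 is no change at the digits printed from compound 2 to compound 3 (within the scatter), that is none beyond the scatter in either direction. Compound 3 is therefore estimated at 57% in this assay, with an expected range from 40% to 75%.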

Compound 3, largest response reached (reported as efficacy), in percent of the reference or control that the assay uses: 72%
Beside the measured number, compound 3's estimate is 15 percentage points below it; the range from low to high includes it.
By their numbers in this assay, from the lowest: compounds 1 and 2 (each within the scatter of the next); then compound 3.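

The series now has its first comparison that differs in one place, and it shows that the maximal response is sensitive to the group on the carbonyl carbon whose other neighbour is the amide-type nitrogen. In this assay methylamino in place of methyl gives a number 15 percentage points higher from compound 2 to compound 3 (beyond the scatter) with the octyl chain, the butyl group and the shared core all unchanged. The entering group brings a nitrogen and a hydrogen-bond donor that the leaving methyl lacks, but nothing at hand bears on what lies behind the step, and this single pair does not separate those two differences.

The compounds shown leave open whether the step depends on the amide hydrogen or on the nitrogen alone, a question that a dimethylamino or a methoxy group on the same carbonyl carbon would address. They also leave open how far the response follows the group on that nitrogen, as an ethylamino group, a longer alkylamino chain or a plain amino group would show.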